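Benzimidazole in Place of Furan: An Expected Small Gain

A few compounds are considered here, and "the series" means these few. Any claim that something is new, unique, unknown or untested is made for them only; others in the source may bear on it.

Measured so far in a functional assay on PC-3 cells (Homo sapiens) for antiproliferative activity, read by CCK-8 assay, with a stated time of 6 days; a lower number here means a stronger inhibitor, a higher number a weaker inhibitor:
Compound 1, `N#Cc1ccc(N2CCc3cc(-c4cnc5ccccc5c4)ccc3C2)cc1C(F)(F)F`: 25100 nM
Compound 2, `N#Cc1ccc(N2CCCc3c(-c4cccnc4)cccc32)cc1C(F)(F)F`: 7970 nM
Compound 3, `CCN(c1ccc(C#N)c(Cl)c1)c1cc(-c2ccoc2)ccc1C`: > 30000 nM (a limit of the assay, not a number)

Compound 1 gives 25100 nM and compound 2 gives 7970 nM, both weak inhibitors with numbers that can be compared. Compound 3 stands apart: its result of > 30000 nM is only a limit, so the assay did not resolve how weak it is. This is the limit of > 30000 nM in this assay, at which 1 of the 3 values shown sits.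

Compound 4, `CCN(c1ccc(C#N)c(Cl)c1)c1cc(-n2cnc3ccccc32)ccc1C`, is the same molecule as compound 3 with one change: 1H-benzimidazol-1-yl in place of furan-3-yl on an aromatic carbon. Among the measured compounds shown here, no pair of measured compounds here differs in one place, so no measured step shows how such a swap plays out. Because compound 3 sits at the limit > 30000 nM, any resolved number for compound 4 would already count as a move toward stronger inhibition. The step of an at least 2.0-fold lower number from compound 3 to compound 4 (0.30 log units; that floor lies within the scatter) is expected to be modest, in the direction of stronger inhibition, and there is a fair chance that compound 4 again returns only a limit. Compound 4 is estimated at 15000 nM, within a range of 3000 nM to 30000 nM.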

Compound 4, half-maximal inhibitory concentration: 8160 nM
The estimate for compound 4 lay 1.8-fold (0.26 log units) above the measured number, and the stated range covers the measured number.
By their numbers in this assay, from the lowest: compounds 2 and 4 (each within the scatter of the next); then compound 1. At a limit, above all of these: compound 3.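

Placing 1H-benzimidazol-1-yl instead of furan-3-yl on this aromatic carbon, para to a methyl group, turns a result without a resolved number into a resolved one in this assay, with an at least 3.6-fold lower number from compound 3 to compound 4 (0.56 log units; beyond the scatter). Among the compounds shown here, this is the first single-place comparison, and it shows that a group with 9 heavy atoms and a second aromatic ring can replace one with 5 heavy atoms here and still give a stronger number. The true size of the step remains unknown because compound 3 gives only a limit: the limit of > 30000 nM in this assay, at which 1 of the 4 values shown sits.

The compounds shown do not reveal whether the added six-membered ring or the change in hetero atoms goes with this gain. On these data alone, how a simple phenyl ring, an amine or a carboxylic acid would read on the same aromatic carbon also remains open.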